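Triazole ethers with varied aryl groups: inhibition in cells

A few compounds are considered here, and "the series" means these few. Any claim that something is new, unique, unknown or untested is made for them only; others in the source may bear on it.

Compound 1, `COc1cccc(-n2cc(COc3ccc4c(c3)CCC4)nn2)c1`, gives 25.8% in an ADME assay on HEK293 cells (Homo sapiens) for inhibition, read by MTT assay, with a stated time of 48 h, tested at 25 uM; on this read-out lower numbers stand for less inhibition and higher numbers for more inhibition at the one concentration tested (going by the name of the read-out).
Compound 2, `c1ccc(-n2cc(COc3ccc4c(c3)CCC4)nn2)cc1`, gives 23.4% in this assay.
Compound 3, `Cc1ccc(-n2cc(COc3ccc4c(c3)CCC4)nn2)cc1`, gives "not determined" (no result reported) in this assay, that is, no result reported.

The three measured compounds share a common core and differ only in the aryl group on the ring nitrogen. Compound 1 and compound 2 sit close together in this assay, and the step of a number 2.4 percentage points lower from compound 1 to compound 2 (within the scatter) shows that removing the methoxy group leaves the read-out essentially unchanged. Going by the values given here, compound 3 carries a 4-methylphenyl group in that position, but no number was obtained for it, so it stands without a reference point of its own; the only guide to where it lies is the pair of neighbouring values from compound 1 and compound 2.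

Compound 4, `Brc1ccccc1-n1cc(COc2ccc3c(c2)CCC3)nn1`, is not yet measured. It differs from compound 3 by 2-bromophenyl in place of 4-methylphenyl on an aromatic nitrogen. Among the compounds with values here, no measured step bears directly on this change; the one available step, within the scatter, concerns a different substituent and only suggests that modest changes to the aryl group have left the read-out flat so far. On that basis compound 4 is expected to give a value near those of compound 1 and compound 2 in this assay, with wide uncertainty. Compound 4 is estimated at 25%, between 8% and 45%.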

Compound 4, a percentage reported as inhibition, at one concentration (the size of the read-out at that concentration, not a potency): 16.5%
Compound 4: the middle estimate sits 8.5 percentage points above what was measured, within the range that was stated.
By their numbers in this assay, from the lowest: compounds 4, 2 and 1 (each within the scatter of the next).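

In this assay, the bromo group on the phenyl ring gives a number 6.9 percentage points lower from compound 2 to compound 4 (within the scatter), so a bromine in this place on the aryl group does not take the read-out outside the usual scatter of the unsubstituted phenyl of compound 2. The exchange of the whole aryl group gives a number 9.3 percentage points lower from compound 1 to compound 4 (within the scatter), so the 2-bromophenyl and 3-methoxyphenyl groups on the aromatic nitrogen cannot be told apart either, and compounds 1, 2 and 4 together show that these three aryl groups are not separated by this read-out at the one concentration tested. No measurement at hand offers an explanation for these values.

The direct change from the 4-methylphenyl group of compound 3 to the 2-bromophenyl group of compound 4 cannot be read, since compound 3 has no number, and the methyl group therefore remains unplaced among these aryl groups. Also open, from the compounds shown here alone, is whether an aryl group carrying an amine or a carboxylic acid would stay as close to these values as the methoxy and bromo groups do.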